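Trimming Benzyl to Propyl on a Shared Core

The source may report more compounds than this note shows. Statements on the series, on what has been measured and on what is new or still open speak of the compounds shown alone.

Three compounds built on one shared core have been compared in an assay on membranes from HEK293 cells for displacement of a labelled ligand from Type-2 angiotensin II receptor (Homo sapiens), read by radioligand binding; on this read-out lower numbers stand for stronger inhibition and higher numbers for weaker inhibition. Compound 1 `CCCCOC(=O)NS(=O)(=O)c1ccc(CCC)cc1-c1ccc(Cn2c(CCCC)nc3ccccc32)cc1` gives 9.2 nM in this assay. Compound 2 `CCCCOC(=O)NS(=O)(=O)c1ccc(CCC)cc1-c1ccc(Cn2cnc3ccccc32)cc1` gives 29 nM, and the step of a 3.2-fold higher number from compound 1 to compound 2 (0.50 log units; beyond the scatter) is the only one here that is clearly beyond the scatter. Compound 3 `CCCCOC(=O)NS(=O)(=O)c1ccc(CCC)cc1-c1ccc(Cn2c(Cc3ccccc3)nc3ccccc32)cc1` gives 15 nM in this assay; on the three numbers it stands second highest, with a 1.6-fold higher number from compound 1 to compound 3 (0.21 log units; within the scatter) and a 1.9-fold lower number from compound 2 to compound 3 (0.29 log units; within the scatter) both within the scatter.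

Compound 4 `CCCCOC(=O)NS(=O)(=O)c1ccc(CCC)cc1-c1ccc(Cn2c(CCC)nc3ccccc32)cc1` has not yet been measured in this assay. It differs from compound 3 by ethyl in place of phenyl on a saturated chain carbon bound to an aromatic carbon. Going by the values given here, the closest measured step is the one between compound 1 and compound 3, where a 1.6-fold higher number from compound 1 to compound 3 (0.21 log units; within the scatter), so swapping a phenyl for a chain on this carbon has so far changed little. Removing the chain entirely, as in compound 2, cost more, but compound 4 keeps a propyl, so only a small step is expected, a 1.3-fold lower number from compound 3 to compound 4 (0.10 log units; within the scatter), within the scatter. For compound 4 the expected value is 12 nM, with a range from 5 nM to 30 nM.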

Compound 4, inhibition constant: 14 nM
Compound 4: the middle estimate sits 1.2-fold (0.07 log units) below what was measured, within the range that was stated.
By their numbers in this assay, from the lowest: compounds 1, 4, 3 and 2 (each within the scatter of the next, the first and the last beyond it).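

In this assay the change from benzyl to propyl gives a 1.1-fold lower number from compound 3 to compound 4 (0.03 log units; within the scatter) and so shows that these two groups, one with a six-membered aromatic ring and one with no ring, read alike at this place. Trimming butyl to propyl gives a 1.5-fold higher number from compound 1 to compound 4 (0.18 log units; within the scatter) and likewise leaves the number within the scatter. Propyl in place of hydrogen on the aromatic carbon gives a 2.1-fold lower number from compound 2 to compound 4 (0.32 log units; beyond the scatter) and so becomes the second group, after butyl, to stand clearly apart from hydrogen, while benzyl in compound 3 goes against this by staying within the scatter of compound 2.

From the compounds shown here alone, whether a longer chain, an amine or a carboxylic acid at this place would keep the number in the same range stays open. No further measurement bears on why these groups read as they do.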